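A few compounds are considered here, and "the series" means these few. Any claim that something is new, unique, unknown or untested is made for them only; others in the source may bear on it.

In an ADME assay on MCF7 cells (Homo sapiens) for cytotoxicity, with a stated time of 72 h (on this read-out lower numbers stand for stronger inhibition and higher numbers for weaker inhibition), compound 1 (`Oc1ccccc1CNc1ncnc2c1ncn2C1CCCCO1`) gives > 100000 nM as a limit and not a number. Compound 2 (`COc1cc(CNc2ncnc3c2ncn3C2CCCCO2)cc(OC)c1OC`) gives > 100000 nM as a limit too. Compound 3 (`Oc1ccccc1CNc1ncnc2c1ncn2C1CCCO1`) gives > 100000 nM as a limit as well, so its standing is known only as a bound. Among the compounds with values here, the series so far reads as the limit of > 100000 nM in this assay, at which 3 of the 3 values shown sit, and offers nothing finer.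

Compound 4 (`COc1cccc(CNc2ncnc3c2ncn3C2CCCO2)c1`) carries 3-methoxyphenyl in place of 2-hydroxyphenyl on a saturated chain carbon bound to a nitrogen on an aromatic ring with the rest unchanged. Within the data shown here, the one measured step, a step that the two limits leave unreadable from compound 1 to compound 3, concerns a different place and gives no size to carry over. The closest guide is compound 2 at > 100000 nM, a limit, which carries methoxy groups and no hydroxy group. No step beyond the scatter is therefore expected in this assay, and another limit is the likeliest report. The estimated a number no higher from compound 3 to compound 4 (the limit leaves the size open) is a nominal figure only. Compound 4 is expected at 100000 nM with an estimated range from 40000 nM to 200000 nM on this read-out.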

Compound 4, half-maximal inhibitory concentration: > 100000 nM
Compound 4 was reported as a limit (the forecaster's own chance of this, stated with the estimate: 85%); the middle value lies on the limit itself.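

Compound 3 and compound 4 are both reported only as limits in this assay, so no step can be read between them. The compounds shown leave open whether any change on the shared core gives a measurable value, since the series still reads as: the limit of > 100000 nM in this assay, at which 4 of the 4 values shown sit.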